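The source may report more compounds than this note shows. Statements on the series, on what has been measured and on what is new or still open speak of the compounds shown alone.

Compound 2 `O=C(Nc1ccccc1)c1cn(Cc2c(F)cccc2F)c2ccc(=O)[nH]c2c1=O` and compound 1 `CC(=O)Nc1ccc(NC(=O)c2cn(Cc3c(F)cccc3F)c3ccc(=O)[nH]c3c2=O)cc1` share one core and differ in a single place, hydrogen in place of acetamido on an aromatic carbon. In an in vitro assay on Sf21 cells for inhibition of high affinity 3',5'-cyclic-AMP phosphodiesterase 7A (Homo sapiens), read by scintillation proximity assay, with a stated time of 30 min (on this read-out lower numbers stand for stronger inhibition and higher numbers for weaker inhibition), compound 1 gives 24 nM and compound 2 gives 94 nM, the higher of the two numbers shown, the only measured step being a 3.9-fold higher number from compound 1 to compound 2 (0.59 log units; beyond the scatter). Compound 3 `O=C(Nc1c(F)cccc1F)c1cn(Cc2c(F)cccc2F)c2ccc(=O)[nH]c2c1=O` keeps the rest of compound 2 unchanged and alters it by 2,6-difluorophenyl in place of phenyl on an amide-type nitrogen. Going by the values given here, no measured step bears on this change: the one known step concerns the aromatic carbon and not the ring on the amide-type nitrogen, and nothing else speaks to the effect of the two fluorines. The expected step is therefore no change at the digits printed from compound 2 to compound 3 (within the scatter), none beyond the scatter, with a wide range to reflect the absence of any comparison. Compound 3 is estimated at 94 nM, between 35 nM and 250 nM.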

Compound 3, half-maximal inhibitory concentration: > 1000 nM
Compound 3: a limit, no number (the forecaster's own chance of this, stated with the estimate: 2%); middle value at least 10-fold (1.02 log units) from the limit.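

Replacing phenyl with 2,6-difluorophenyl on the amide-type nitrogen gives an at least 10-fold higher number from compound 2 to compound 3 (1.02 log units; beyond the scatter), so this ring responds to substitution in a way that the earlier acetamido step, a 3.9-fold higher number from compound 1 to compound 2 (0.59 log units; beyond the scatter), did not reveal. The change of 4-acetamidophenyl to 2,6-difluorophenyl at the same place gives an at least 41-fold higher number from compound 1 to compound 3 (1.61 log units; beyond the scatter), so the acetamido group of compound 1 does not carry over to a ring of this kind. Compound 3 has no number in this assay, only a limit: the limit of > 1000 nM in this assay, at which 1 of the 3 values shown sits.

Open, going by these compounds, is how far compound 3 lies past that limit, and whether the fluorines act together or singly, a question that a phenyl ring carrying a single fluorine would address. Also open, on these data alone, is how a ring with methyl or chlorine in place of the two fluorines, or a phenyl carrying a carboxylic acid or an amine, would read at this place.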